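This account rests on a few compounds, and the source may have more. Where it says the series, first, only, none or still open, it means among the compounds named here.

Compound 1 `O=S(=O)(NCCCCNCc1ccc(Br)cc1)c1cc(C(F)(F)F)cc(C(F)(F)F)c1`: 1900 nM
Compound 2 `COc1ccc(CNCCCNS(=O)(=O)c2cc(C(F)(F)F)cc(C(F)(F)F)c2)cc1OC`: 15000 nM
Compound 3 `CN(CCCNS(=O)(=O)c1cc(C(F)(F)F)cc(C(F)(F)F)c1)Cc1ccccc1`: 46000 nM

In a functional assay on Capan-2 cells (Homo sapiens) for inhibition, read by MTT assay, with a stated time of 72 h (a higher number here means a weaker inhibitor of growth, a lower number a stronger inhibitor of growth), compound 2 gives the second highest of the three numbers, sitting between compound 1 at 1900 nM and compound 3 at 46000 nM, beyond the scatter from each. Compound 4 `O=S(=O)(NCCCNCc1cccc2ccccc12)c1cc(C(F)(F)F)cc(C(F)(F)F)c1` differs from compound 2 by naphthalen-1-yl in place of 3,4-dimethoxyphenyl on a saturated chain carbon bound to an amine nitrogen. Among the measured compounds shown here, no measured step swaps this ring alone. For the measured compounds named here, the one measured step, a 24-fold higher number from compound 1 to compound 3 (1.38 log units; beyond the scatter), reworks the same amine-bearing end of the chain and is large, so changes here clearly matter. Compound 1, whose ring carries a bromo group, gives the lowest number of the set. A moderate move toward lower numbers is therefore expected, a 3.3-fold lower number from compound 2 to compound 4 (0.52 log units; beyond the scatter), with wide uncertainty. Compound 4 is estimated at 4500 nM, within 1500 nM to 14000 nM.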

Compound 4, concentration for 50% growth inhibition: 2700 nM
Compound 4: middle estimate off by 1.7-fold (0.22 log units), on the high side; the range from low to high includes it.
By their numbers in this assay, from the lowest: compounds 1 and 4 (each within the scatter of the next); then compound 2; then compound 3.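

In this assay the change gives a 5.6-fold lower number from compound 2 to compound 4 (0.74 log units; beyond the scatter) with only the ring altered, showing that this place, on a saturated chain carbon bound to an amine nitrogen, responds to the ring alone. The swap removes the hydrogen-bond acceptors and adds aromatic ring at once, so the two differences cannot be separated. No measurement at hand explains the fall in the number. Open, from the compounds shown here alone, is how a naphthalen-2-yl group, attached through the other ring carbon, would compare. A phenyl ring carrying a single methoxy group would help separate the two differences.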